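Hydroxyethyl isomers on the shared core of compound 2

This account rests on a few compounds, and the source may have more. Where it says the series, first, only, none or still open, it means among the compounds named here.

Two compounds carry the shared core with a triazole substituent and have numbers in a functional assay on HL-60 cells (Homo sapiens) for inhibition, read by MTT assay, with a stated time of 72 h; a lower number here means a stronger inhibitor, a higher number a weaker inhibitor. Compound 1 `COc1ccc(-c2cn(-c3ccc(C)c(Nc4nccc(-c5cccnc5)n4)c3)nn2)cc1C(F)(F)F` gives 21200 nM. Compound 2 `Cc1ccc(-n2cc(C(C)O)nn2)cc1Nc1nccc(-c2cccnc2)n1` gives 25500 nM; the step of a 1.2-fold higher number from compound 1 to compound 2 (0.08 log units; within the scatter) shows that a large aryl group and 1-hydroxyethyl at this position give values within the scatter of each other. Compound 3 `Cc1ccc(-n2cc(CCO)nn2)cc1Nc1nccc(-c2cccnc2)n1` differs from compound 2 by 2-hydroxyethyl in place of 1-hydroxyethyl on an aromatic carbon. For the measured compounds named here, no measured step tests this rearrangement; only the step from compound 1 to compound 2 touches the same position, and it lies within the scatter. For compound 3 no shift beyond the scatter is expected in this assay, a 1.0-fold lower number from compound 2 to compound 3 (0.01 log units; within the scatter), so the estimate is 25000 nM, in the range 10000 nM to 60000 nM.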

Compound 3, half-maximal inhibitory concentration: 9100 nM
Compound 3: middle estimate off by 2.7-fold (0.44 log units), on the high side; measured number outside the range, below it.
By their numbers in this assay, from the lowest: compound 3; then compounds 1 and 2 (each within the scatter of the next).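

At this position in this assay, the arrangement of the hydroxyethyl group matters, if modestly: with the same atoms joined differently, 2-hydroxyethyl in place of 1-hydroxyethyl gives a step beyond the scatter (a 2.8-fold lower number from compound 2 to compound 3 (0.45 log units; beyond the scatter)). Unlike 1-hydroxyethyl, 2-hydroxyethyl also separates from 4-methoxy-3-(trifluoromethyl)phenyl (a 2.3-fold lower number from compound 1 to compound 3 (0.37 log units; beyond the scatter)). No available data account for this shift.

Going by these compounds, whether the lower number depends on the terminal hydroxyl or on the chain itself remains open. A 3-hydroxypropyl chain or a 2-aminoethyl group at this position would bear on that question.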